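Swapping furan-3-yl for 1-benzofuran-2-yl at the assay limit

The source may hold more compounds than are shown below. What is called first, only, known or untested is meant among the compounds shown, and "the series" means these compounds.

Compound 1 `OC[C@H]1O[C@@H](n2cc(F)c3c(-c4ccoc4)ncnc32)[C@H](O)[C@@H]1O`: 15400 nM
Compound 2 `CCCCCCCCCCCCCCCCCCOP(=O)(O)OC[C@H]1O[C@@H](n2ccc3c(-c4ccoc4)ncnc32)[C@H](O)[C@@H]1O`: > 50000 nM

Both compounds were tested in an ADME assay on MRC5 cells (Homo sapiens) for cytotoxicity, read by MTT assay, with a stated time of 72 h; a lower number here means that less compound is tolerated, a higher number that more compound is tolerated. Compound 1 gives a number there, 15400 nM. From the compounds shown here alone, compound 2 gives only a limit, > 50000 nM, and not a number, so its true position in this assay is unknown.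

Compound 3 `CCCCCCCCCCCCCCCCCCOP(=O)(O)OC[C@H]1O[C@@H](n2ccc3c(-c4cc5ccccc5o4)ncnc32)[C@H](O)[C@@H]1O` follows from compound 2 by one change: 1-benzofuran-2-yl in place of furan-3-yl on an aromatic carbon of a six-membered aromatic ring with 2 nitrogen (1-benzofuran-2-yl in place of furan-3-yl on an aromatic carbon). The rest of the structure stays the same.

Going by the values given here, no pair of measured compounds differs in one place, so no measured step can guide the size of this one. The expectation rests on compound 2 with its > 50000 nM alone. No step beyond the usual scatter is expected in this assay, and any step that does appear is expected to lean towards less compound being tolerated. The estimated change is an at least 1.2-fold lower number from compound 2 to compound 3 (0.09 log units; that floor lies within the scatter). A limit rather than a number may well be reported again. For compound 3 the expected value is 40000 nM, within an estimated range of 15000 nM to 80000 nM.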

Compound 3, half-maximal cytotoxic concentration: > 50000 nM
Compound 3: only a limit was reported (the forecaster's own chance of this, stated with the estimate: 55%); middle value at least 1.2-fold (0.09 log units) away from the limit.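

In this assay, compound 2 and compound 3 each give only a limit and not a number, so no step between them can be read: the limit of > 50000 nM in this assay, at which 2 of the 3 values shown sit.

The compounds shown leave open where compound 2 and compound 3 truly stand in this assay, and whether 1-benzofuran-2-yl in place of furan-3-yl shifts the number at all.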